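Three Inactive Analogues and a Hydroxy-for-Cyano Variant

A few compounds are considered here, and "the series" means these few. Any claim that something is new, unique, unknown or untested is made for them only; others in the source may bear on it.

Measured compounds:
compound 1, `CCCNc1ncnc2c1ncn2C[C@@H]1C[C@H](CO)c2ccccc21`: > 200000 nM
compound 2, `N#Cc1cn([C@H]2C[C@H](O)[C@@H](CO)O2)c(=O)[nH]c1=O`: > 200000 nM
compound 3, `O=c1[nH]cnc2c1nnn2CC1CCC(CO)C1`: > 200000 nM

In an ADME assay on L1210/0 cells (Mus musculus) for cytotoxicity, with a stated time of 48 h (on this read-out higher numbers stand for weaker inhibition and lower numbers for stronger inhibition), compound 1 gives > 200000 nM, which is a limit of the assay and not a number. In this assay compound 2 likewise gives > 200000 nM, again a limit rather than a measured number. Compound 3 in this assay also gives > 200000 nM, a limit once more.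

Among the compounds with values here, compound 2 therefore stands exactly where the other two compounds stand: every value shown is the limit of > 200000 nM in this assay, at which 3 of the 3 values shown sit, so there is no measured number anywhere to set compound 2 against, and no step between measured compounds can be drawn.

Compound 4 `O=c1[nH]c(=O)n([C@H]2C[C@H](O)[C@@H](CO)O2)cc1O` is the compound yet to be measured. It differs from compound 2 by hydroxy in place of cyano on an aromatic carbon. With all three known values sitting at the same limit, there is no basis for expecting a move in either direction, and the step that the limit leaves unreadable from compound 2 to compound 4 in this assay is expected to be none beyond the scatter. Compound 4 is estimated in this assay at 300000 nM, within a range from 100000 nM to 1000000 nM, most likely reported again only as a limit.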

Compound 4, half-maximal inhibitory concentration: > 200000 nM
Compound 4: a limit, no number; the forecaster's own chance of this, stated with the estimate: 85%; the middle value is on the limit's open side.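

In this assay compound 4 gives > 200000 nM, a limit of the assay and not a number. No step from compound 2 to compound 4 can be read, because both compounds rest on the same limit: the limit of > 200000 nM in this assay, at which 4 of the 4 values shown sit.

The compounds shown leave open whether hydroxy in place of cyano on an aromatic carbon changes the read-out in this assay at all.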